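A few compounds are considered here, and "the series" means these few. Any claim that something is new, unique, unknown or untested is made for them only; others in the source may bear on it.

Compound 1 `CCCCCCCCCCCCCCCCCCNC(=O)[C@H]1CSC(C2CCCCC2)N1` carries a cyclohexyl on a saturated ring carbon of the shared core. In a functional assay on DU-145 cells (Homo sapiens) for antiproliferative activity, read by sulforhodamine B assay (on this read-out lower numbers stand for stronger inhibition and higher numbers for weaker inhibition), compound 1 gives > 20000 nM, which is a limit of the assay and not a number. Compound 2 `CCCCCCCCCCCCCCCCCCNC(=O)[C@H]1CSC(c2ccc(F)cc2)N1` has a 4-fluorophenyl in that position. In this assay, going by the values given here, compound 2 gives 5700 nM, the only number among the values shown. The other value, that of compound 1, is a limit (the limit of > 20000 nM in this assay, at which 1 of the 2 values shown sits). Among the compounds with values here, the step of an at least 3.5-fold lower number from compound 1 to compound 2 (0.54 log units; beyond the scatter) is the only measured step. Compound 3 `CCCCCCCCCCCCCCCCCCNC(=O)[C@H]1CSC(c2ccc([N+](=O)[O-])cc2)N1` differs from compound 2 by nitro in place of fluoro on an aromatic carbon. Within the data shown here, no measured step alters a group on the aromatic ring; the single measured step concerned the saturated ring carbon instead, so it offers no direct guide to this change. A step within the scatter is therefore expected, a 1.3-fold lower number from compound 2 to compound 3 (0.10 log units; within the scatter). For compound 3 in this assay a value of 4500 nM is expected, with a range from 1500 nM to 15000 nM.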

Compound 3, half-maximal inhibitory concentration: 15300 nM
Compound 3: middle estimate off by 3.4-fold (0.53 log units), on the low side, and the stated range ends below it.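

In this assay the group on the aromatic ring clearly counts: nitro in place of fluoro gives a 2.7-fold higher number from compound 2 to compound 3 (0.43 log units; beyond the scatter). Replacing cyclohexyl with 4-nitrophenyl gives an at least 1.3-fold lower number from compound 1 to compound 3 (0.11 log units; that floor lies within the scatter), so the compounds shown do not establish that an aromatic ring in this place is enough on its own for a step beyond the scatter. That comparison rests on compound 1, whose value is a limit of the assay and not a number: the limit of > 20000 nM in this assay, at which 1 of the 3 values shown sits.

Going by these compounds, with only fluoro and nitro on the aromatic ring, it remains open how an unsubstituted phenyl, an amine or a carboxylic acid in that place would read in this assay. Also open, on these data alone, is whether these steps would hold with a shorter chain on the amide nitrogen.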